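This account rests on a few compounds, and the source may have more. Where it says the series, first, only, none or still open, it means among the compounds named here.

Compound 1 `CNC(=O)CCSc1ccc2c(/C=C/c3ccccn3)n[nH]c2c1` carries a small methyl amide on the shared core. In an ADME assay on BaF3 cells (Mus musculus) for antiproliferative activity, read by CCK-8 assay, with a stated time of 72 h (on this read-out lower numbers stand for stronger inhibition of growth and higher numbers for weaker inhibition of growth), compound 1 gives > 10000 nM, which is a limit of the assay and not a number. Going by the values given here, the one measured neighbour is compound 2 `CN(C)c1cccc(NC(=O)CCSc2ccc3c(/C=C/c4ccccn4)n[nH]c3c2)c1`, and in this assay compound 2 gives > 10000 nM, again only a limit. The step that the two limits leave unreadable from compound 1 to compound 2 is therefore unreadable because of the limit of > 10000 nM in this assay, at which 2 of the 2 values shown sit. Compound 3 `Cc1ccc(NC(=O)CCSc2ccc3c(/C=C/c4ccccn4)n[nH]c3c2)cc1C(F)(F)F` differs from compound 1 by 4-methyl-3-(trifluoromethyl)phenyl in place of methyl on an amide-type nitrogen. This change resembles the aryl replacement between compound 1 and compound 2, which the two limits leave unresolved, so no direction beyond the scatter can be read for this assay. The step of a number no higher from compound 1 to compound 3 (the limit leaves the size open) is expected to be small and uncertain. Compound 3 is accordingly estimated at 10000 nM, within 3000 nM to 30000 nM, in this assay, with a limit the likeliest report once more.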

Compound 3, concentration for 50% growth inhibition: 530 nM
The estimate for compound 3 lay 19-fold (1.28 log units) above the measured number; the whole stated range lies above it.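

In this assay, the amide nitrogen turns out to be a place where growth inhibition can be gained: 4-methyl-3-(trifluoromethyl)phenyl in place of methyl gives an at least 18-fold lower number from compound 1 to compound 3 (1.27 log units; beyond the scatter). An aryl ring on this nitrogen does not settle the outcome by itself, since exchanging 3-(dimethylamino)phenyl for 4-methyl-3-(trifluoromethyl)phenyl gives an at least 18-fold lower number from compound 2 to compound 3 (1.27 log units; beyond the scatter), so the groups carried on that ring matter here. The step from compound 1 to compound 2 still cannot be read, and the two new steps give only a smallest possible size because of the assay limit: the limit of > 10000 nM in this assay, at which 2 of the 3 values shown sit.

The compounds shown do not tell whether the methyl, the trifluoromethyl or the two together account for the gain in compound 3. Nor do they show how a phenyl ring bearing a carboxylic acid or a morpholine on this amide nitrogen would behave.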